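This account rests on a few compounds, and the source may have more. Where it says the series, first, only, none or still open, it means among the compounds named here.

Measured compounds:
compound 1 `CCn1c(C(=O)NCCN)ccc1C(CC)(CC)c1ccc(OCS(=O)(=O)c2ccccc2)c(C)c1` gives 6470 nM
compound 2 `CCn1c(C(=O)N[C@@H](C)CO)ccc1C(CC)(CC)c1ccc(OCS(=O)(=O)c2ccccc2)c(C)c1` gives 10800 nM
compound 3 `CCn1c(C(=O)NC(C)(C)CO)ccc1C(CC)(CC)c1ccc(OCS(=O)(=O)c2ccccc2)c(C)c1` gives 20700 nM

In a functional assay on MCF7 cells (Homo sapiens) for antiproliferative activity, read by MTT assay, with a stated time of 24 h (on this read-out higher numbers stand for weaker inhibition and lower numbers for stronger inhibition), the three compounds differ only in the group on the amide-type nitrogen. Compound 3 has the highest number of the three; its nearest neighbour is compound 2, with a 1.9-fold higher number from compound 2 to compound 3 (0.28 log units; within the scatter), and the step of a 3.2-fold higher number from compound 1 to compound 3 (0.51 log units; beyond the scatter) is the only one that clears the scatter. Compound 4 `CCn1c(C(=O)N[C@@H](C)C(=O)O)ccc1C(CC)(CC)c1ccc(OCS(=O)(=O)c2ccccc2)c(C)c1` continues this series with the change (1-carboxyethyl in place of 1-(hydroxymethyl)-1-methylethyl on an amide-type nitrogen). Among the compounds with values here, no measured step swaps a hydroxyl-bearing group for a carboxylic acid, so the closest guide is the pair of modest upward steps a 1.7-fold higher number from compound 1 to compound 2 (0.22 log units; within the scatter) and a 1.9-fold higher number from compound 2 to compound 3 (0.28 log units; within the scatter), which show that changes on this nitrogen have moved the number only a little, and always upward from compound 1. A step of similar size, upward or none beyond the scatter, is therefore expected here, giving a 1.3-fold higher number from compound 3 to compound 4 (0.10 log units; within the scatter). Compound 4 is estimated at 26000 nM, with a range from 9000 nM to 70000 nM.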

Compound 4, half-maximal inhibitory concentration: 35500 nM
Compound 4: middle estimate off by 1.4-fold (0.14 log units), on the low side, and the stated range covers the measured number.
By their numbers in this assay, from the lowest: compounds 1, 2, 3 and 4 (each within the scatter of the next, the first and the last beyond it).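

In this assay, within the data shown here, compound 4 gives the first direct reading of carboxy in place of hydroxymethyl on this chain carbon, and that change clears the scatter: a 3.3-fold higher number from compound 2 to compound 4 (0.52 log units; beyond the scatter). The 1-carboxyethyl group also gives the largest step on the amide-type nitrogen among these compounds, a 5.5-fold higher number from compound 1 to compound 4 (0.74 log units; beyond the scatter), while a 1.7-fold higher number from compound 3 to compound 4 (0.23 log units; within the scatter) leaves it indistinguishable from 1-(hydroxymethyl)-1-methylethyl. Nothing given here bears on the cause of these steps.

Still open, going by these compounds, is whether the methyl ester or the primary amide of the carboxylic acid would fall nearer compound 2 or compound 4. On these data alone, it is equally open whether a longer chain carrying the amine would bring the number below that of compound 1.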